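Linker swap on the diamino core: sulfanyl to benzylamino

A few compounds are considered here, and "the series" means these few. Any claim that something is new, unique, unknown or untested is made for them only; others in the source may bear on it.

Compound 1 `Nc1cc(N)c2nc(-c3ccccc3)c(Sc3ccc(F)cc3)nc2c1` is the reference of this set. In a functional assay on OVCAR-4 cells (Homo sapiens) for inhibition, read by sulforhodamine B assay, with a stated time of 48 h (on this read-out higher numbers stand for weaker inhibition of growth and lower numbers for stronger inhibition of growth), compound 1 gives 56200 nM, the lowest of the numbers shown. Compound 3 `CCOC(=O)[C@H](CCC(=O)O)NC(=O)c1ccc(CNc2nc3cc(N)cc(N)c3nc2-c2ccccc2)cc1` gives 79400 nM in this assay, which sits within the scatter of compound 1. Compound 2 `CCOC(=O)[C@H](CCC(=O)O)NC(=O)c1ccc(Oc2nc3cc(N)cc(N)c3nc2-c2ccccc2)cc1` reaches only a limit in this assay, < 100000 nM, and (the limit of < 100000 nM in this assay, at which 1 of the 3 values shown sits). Compound 4 `Nc1cc(N)c2nc(-c3ccccc3)c(NCc3ccc(F)cc3)nc2c1` is not yet measured; it differs from compound 1 by (4-fluorobenzyl)amino in place of (4-fluorophenyl)sulfanyl on an aromatic carbon. For the measured compounds named here, no measured pair isolates this change, so the step from compound 1 to compound 4 is expected to stay within the scatter, with no clear direction, giving a 1.1-fold higher number from compound 1 to compound 4 (0.03 log units; within the scatter). Compound 4 is therefore estimated at 60000 nM in this assay, between 25000 nM and 150000 nM.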

Compound 4, concentration for total growth inhibition: 8130 nM
The estimate for compound 4 lay 7.4-fold (0.87 log units) above the measured number, outside the stated range (below it).
By their numbers in this assay, from the lowest: compound 4; then compounds 1 and 3 (each within the scatter of the next).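

In this assay, this position, next to the ring nitrogen and ortho to a phenyl group, proves sensitive to the linking group: (4-fluorobenzyl)amino in place of (4-fluorophenyl)sulfanyl gives a 6.9-fold lower number from compound 1 to compound 4 (0.84 log units; beyond the scatter). For the compounds shown here, this is the only step that isolates one place, and it lies beyond the scatter. No measurement shown gives a reason for it.

The change alters the linking atom and adds a carbon at once, so their shares remain unresolved. A (4-fluorophenyl)amino or (4-fluorobenzyl)sulfanyl group at this position would separate them.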